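A few compounds are considered here, and "the series" means these few. Any claim that something is new, unique, unknown or untested is made for them only; others in the source may bear on it.

Measured compounds:
compound 1 `Nc1nc(Cl)c2ncn(Cc3ccccc3CCl)c2n1` — 38000 nM
compound 2 `ClCc1ccccc1Cn1cnc2nc(Cl)nc(Cl)c21` — 4160 nM

The study follows cytotoxicity in a functional assay on UACC-257 cells (Homo sapiens) for cytotoxicity, read by sulforhodamine B assay, with a stated time of 48 h; on this read-out higher numbers stand for weaker inhibition of growth and lower numbers for stronger inhibition of growth. Of the two measured compounds, compound 2 `ClCc1ccccc1Cn1cnc2nc(Cl)nc(Cl)c21` gives the lowest number, 4160 nM. Within the data shown here, compound 1 gives 38000 nM, a higher number that lies beyond the usual scatter; no single-change step links the two, so only their values themselves can be compared.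

Compound 3 `ClCc1ccccc1Cn1cnc2ncnc(Cl)c21` has not yet been measured in this assay. It differs from compound 2 in one place: hydrogen in place of chloro on an aromatic carbon. Among the measured compounds shown here, no measured pair shows what this change alone does, so the account of compound 3 rests on compound 2 alone. A modest weakening is expected here, since the shared core is left with one chloro group fewer, though the change could also fall within the scatter. The step from compound 2 to compound 3 is estimated as a 2.2-fold higher number from compound 2 to compound 3 (0.34 log units; beyond the scatter). Compound 3 is expected to give about 9000 nM, with a range from 3000 nM to 30000 nM.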

Compound 3, concentration for total growth inhibition: 21900 nM
Beside the measured number, compound 3's estimate is 2.4-fold (0.39 log units) below it; the range from low to high includes it.
By their numbers in this assay, from the lowest: compound 2; then compounds 3 and 1 (each within the scatter of the next).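

In this assay, among these compounds, hydrogen in place of chloro on the aromatic carbon between two ring nitrogen atoms gives a 5.3-fold higher number from compound 2 to compound 3 (0.72 log units; beyond the scatter), the first single change whose effect can be read. In this pair, the chloro group at this position goes with stronger inhibition of growth, and its loss cannot be put down to the usual scatter. Nothing measured here explains why the number rises.

From the compounds shown here alone, whether a fluoro, methyl or methoxy group on this carbon would keep the number of compound 2 remains open, as does whether the chloro group meta to this position matters to a similar degree. Among the compounds shown here, with only this pair to go on, it is also unknown whether the same change would have a similar effect on a different shared core.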